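Series notes: trimming the side chain of compound 3

The source may report more compounds than this note shows. Statements on the series, on what has been measured and on what is new or still open speak of the compounds shown alone.

In a functional assay on MCF7 cells (Homo sapiens) for cytotoxicity, read by MTT assay, with a stated time of 72 h (on this read-out higher numbers stand for weaker inhibition and lower numbers for stronger inhibition), compound 3 (`COc1ncc(-c2ccc3nc(NC(=O)NCCN4CCN(C)CC4)nn3c2)cc1NS(=O)(=O)c1ccc(F)cc1`) gives 500 nM. Compound 1 (`COc1ncc(-c2ccc3nc(NC(=O)NCC(=O)N4CCCCC4)nn3c2)cc1NS(=O)(=O)c1ccc(F)cc1`) gives 570 nM, and the two cannot be told apart: a 1.1-fold lower number from compound 1 to compound 3 (0.06 log units; within the scatter). Going by the values given here, compound 2 (`COc1ncc(-c2ccc3nc(NC(=O)N(C)C)nn3c2)cc1NS(=O)(=O)c1ccc(F)cc1`) gives 1560 nM, the one clearly separate value, as a 2.7-fold higher number from compound 1 to compound 2 (0.44 log units; beyond the scatter) also shows.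

Compound 4 (`CNC(=O)Nc1nc2ccc(-c3cnc(OC)c(NS(=O)(=O)c4ccc(F)cc4)c3)cn2n1`) is still unmeasured. The change is hydrogen in place of (4-methylpiperazin-1-yl)methyl on a saturated chain carbon bound to an amide-type nitrogen. In words, hydrogen stands in place of (4-methylpiperazin-1-yl)methyl on a saturated chain carbon bound to an amide-type nitrogen, so that (2-(4-methylpiperazin-1-yl)ethyl)amino becomes methylamino.

Among the compounds with values here, no measured step makes exactly this change. The closest is the one that replaces dimethylamino with (2-(4-methylpiperazin-1-yl)ethyl)amino: a 3.1-fold lower number from compound 2 to compound 3 (0.49 log units; beyond the scatter), a modest step beyond the scatter. Compound 4 carries methylamino, so compound 2, at 1560 nM, is the nearest guide, and the step is read in reverse. What a single methyl on that nitrogen does, compared with two, has not been measured.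

The expected step is a 2.6-fold higher number from compound 3 to compound 4 (0.41 log units; beyond the scatter), of modest size and towards a higher number. For compound 4 the estimate is 1300 nM, with an expected range of 550 nM to 3000 nM.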

Compound 4, half-maximal inhibitory concentration: 250 nM
The estimate for compound 4 lay 5.2-fold (0.72 log units) above the measured number; the whole stated range lies above it.
By their numbers in this assay, from the lowest: compounds 4, 3 and 1 (each within the scatter of the next, the first and the last beyond it); then compound 2.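

Nearly all of the side chain can go from this position in this assay: with hydrogen in place of (4-methylpiperazin-1-yl)methyl on the saturated chain carbon bound to an amide-type nitrogen, the result is a 2.0-fold lower number from compound 3 to compound 4 (0.30 log units; within the scatter), so the 4-methylpiperazine ring gives no measurable gain over the plain methyl of methylamino, while replacing the (piperidin-1-yl)carbonyl of the other long chain gives a 2.3-fold lower number from compound 1 to compound 4 (0.36 log units; beyond the scatter). The sharper contrast lies at the nitrogen itself, where hydrogen in place of methyl gives a 6.2-fold lower number from compound 2 to compound 4 (0.80 log units; beyond the scatter), a step that shows one methyl on that nitrogen separating two otherwise identical compounds and places compound 2, the only one of the four without a hydrogen there, apart from the rest. Nothing on hand accounts for either the flat response to the side chain or the sensitivity to the second methyl.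

The compounds shown leave open whether an ethyl group, a longer unbranched alkyl chain or a chain ending in a carboxylic acid on this nitrogen would stay with compound 4 or move away from it. They also leave open how the unsubstituted urea, with an amino group in place of methylamino, would compare.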